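Notes on the step from compound 3 to compound 4

A few compounds are considered here, and "the series" means these few. Any claim that something is new, unique, unknown or untested is made for them only; others in the source may bear on it.

Measured so far in a functional assay on MKN-74 cells (Homo sapiens) for antiproliferative activity, with a stated time of 24 h; on this read-out lower numbers stand for stronger inhibition and higher numbers for weaker inhibition:
compound 1 `Cc1ccccc1CN1CCc2c(sc(NC(=O)c3ccccc3Cl)c2C(N)=O)C1`: compound 1 gives > 50000 nM, which is a limit of the assay and not a number.
compound 2 `NC(=O)c1c(NC(=O)c2ccccc2Cl)sc2c1CCN(Cc1ccc(Cl)cc1)C2`: compound 2 gives 18700 nM.
compound 3 `NC(=O)c1c(NC(=O)c2ccccc2Cl)sc2c1CCN(C(=S)Nc1ccccc1I)C2`: compound 3 gives 2630 nM.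

Compound 3 stands lowest of the two numbers shown, separated by a 7.1-fold lower number from compound 2 to compound 3 (0.85 log units; beyond the scatter); the further step an at least 19-fold lower number from compound 1 to compound 3 (1.27 log units; beyond the scatter) is measured only against the limit of > 50000 nM in this assay, at which 1 of the 3 values shown sits, and is a lower bound on its size.

Compound 4 `NC(=O)c1c(NC(=O)c2ccccc2Cl)sc2c1CCN(C(=S)Nc1ccc(C(F)(F)F)cc1)C2` differs from compound 3 by 4-(trifluoromethyl)phenyl in place of 2-iodophenyl on an amide-type nitrogen. Within the data shown here, no measured step changes this aryl group while keeping the thiocarbonyl linkage. Among the measured compounds shown here, the nearest precedent is an at least 2.6-fold lower number from compound 1 to compound 2 (0.42 log units; beyond the scatter), where 4-chlorophenyl replaced 2-methylphenyl, though that change sat on a saturated chain carbon bound to an amine nitrogen in a ring, not on the amide-type nitrogen bound to the thiocarbonyl carbon. On that precedent a small to modest lowering of the number in this assay is expected, a 1.8-fold lower number from compound 3 to compound 4 (0.24 log units; within the scatter), with wide uncertainty. Compound 4 is expected to give about 1500 nM, within 400 nM to 6000 nM.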

Compound 4, half-maximal inhibitory concentration: 7090 nM
Compound 4: the middle estimate sits 4.7-fold (0.67 log units) below what was measured; measured number above the stated range.
By their numbers in this assay, from the lowest: compound 3; then compound 4; then compound 2. At a limit, above all of these: compound 1.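

The aryl group on the amide-type nitrogen bound to the thiocarbonyl carbon does affect the read-out in this assay: replacing 2-iodophenyl with 4-(trifluoromethyl)phenyl gives a 2.7-fold higher number from compound 3 to compound 4 (0.43 log units; beyond the scatter) and thus a weaker result. The direction differs from that of an at least 2.6-fold lower number from compound 1 to compound 2 (0.42 log units; beyond the scatter), so the earlier change of aryl group on a saturated chain carbon does not carry over to this nitrogen. Nothing measured in this set gives a cause for the new step:.

Among these compounds, the single step changes both the substituent and its place on the ring, and the two contributions cannot be separated from compound 3 and compound 4 alone. Also open, going by these compounds, is how this position would respond to an unsubstituted phenyl, or to an aryl ring carrying a nitrile, an amine or a carboxylic acid.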